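The source may report more compounds than this note shows. Statements on the series, on what has been measured and on what is new or still open speak of the compounds shown alone.

Measured compounds in an ADME assay on NIH3T3 cells (Mus musculus) for cytotoxicity, read by MTT assay, with a stated time of 24 h; on this read-out lower numbers stand for stronger inhibition and higher numbers for weaker inhibition:
- Compound 1, `Cc1nnc(SCC(=O)N/N=c2/scc(-c3ccc(C#N)cc3)n2-c2ccccc2)s1`; the assay reports only a limit for compound 1, < 3.9 ug/mL.
- Compound 2, `COc1ccc(-c2cs/c(=N/NC(=O)CSc3nnc(C)s3)n2-c2ccccc2)cc1`; compound 2 gives 300 ug/mL.
- Compound 3, `O=C(CSc1nnnn1-c1ccccc1)N/N=c1/scc(-c2ccc(Cl)cc2)n1-c1ccccc1`; compound 3 gives 313 ug/mL.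

Compound 3 stands highest of the two numbers, with compound 2 nearest; the gap between them lies within the scatter, so no order between them is claimed. Compound 4, `Cc1nnc(SCC(=O)N/N=c2/scc(-c3ccc(Cl)cc3)n2-c2ccccc2)s1`, is not yet measured and differs from compound 3 in one place: 5-methyl-1,3,4-thiadiazol-2-yl in place of 1-phenyl-1H-tetrazol-5-yl on a sulfur. Among the measured compounds shown here, the only measured step, an at least 76-fold higher number from compound 1 to compound 2 (1.88 log units; beyond the scatter), concerns a substituent on an aromatic carbon elsewhere in the shared core and does not bear on the sulfur-attached ring. The 5-methyl-1,3,4-thiadiazol-2-yl group already appears in compound 1, which sits at the limit of < 3.9 ug/mL in this assay, at which 1 of the 3 values shown sits. It also appears in compound 2, which gives a high number. For the measured compounds named here, no measured pair compares the two sulfur-attached rings directly, so no step beyond the scatter is expected. Compound 4 is expected to give about 250 ug/mL, between 50 ug/mL and 450 ug/mL. The expected step from compound 3 is a 1.3-fold lower number from compound 3 to compound 4 (0.10 log units; within the scatter), within the scatter.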

Compound 4, half-maximal inhibitory concentration: 253 ug/mL
Beside the measured number, compound 4's estimate is 1.0-fold (0.01 log units) below it, within the range that was stated.
By their numbers in this assay, from the lowest: compounds 4, 2 and 3 (each within the scatter of the next). At a limit, below all of these: compound 1.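

In this assay, the sulfur-attached ring can be exchanged with a 1.2-fold lower number from compound 3 to compound 4 (0.09 log units; within the scatter), so on a sulfur whose other neighbours are a saturated chain carbon, 5-methyl-1,3,4-thiadiazol-2-yl and 1-phenyl-1H-tetrazol-5-yl read alike, although only the second carries a six-membered aromatic ring of carbon only. With 5-methyl-1,3,4-thiadiazol-2-yl held constant, the aromatic carbon shows a 1.2-fold lower number from compound 2 to compound 4 (0.07 log units; within the scatter) for chloro in place of methoxy but an at least 64-fold higher number from compound 1 to compound 4 (1.81 log units; beyond the scatter) for chloro in place of cyano, so among these three substituents only the cyano compound stands apart. Compound 1 carries a limit rather than a number: the limit of < 3.9 ug/mL in this assay, at which 1 of the 4 values shown sits.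

On these data alone, whether a nitro group or a carboxylic acid on that aromatic carbon would give a low number like the cyano compound remains open. Also open, as far as these compounds go, is whether a sulfur-attached alkyl chain or an amine-bearing ring would read like the two rings compared here.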